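The source may hold more compounds than are shown below. What is called first, only, known or untested is meant among the compounds shown, and "the series" means these compounds.

Measured so far, in a functional assay on HEK293 cells for agonist activity at Neuronal acetylcholine receptor; alpha4/beta2 (Homo sapiens), read by FLIPR; on this read-out higher numbers stand for an effect only at larger amounts of compound and lower numbers for an effect already at smaller amounts:
Compound 1, `Brc1cncc(N2CC[C@H]3CN[C@H]3C2)c1`, gives 150 nM.
Compound 2, `Brc1cncc(N2CC[C@@H]3CN[C@@H]3C2)c1`, gives 1000 nM.

Among the measured compounds shown here, compound 2 stands at the highest of the two numbers, with compound 1 as its only neighbour. For the measured compounds named here, the one step seen so far, a 6.7-fold higher number from compound 1 to compound 2 (0.82 log units; beyond the scatter), rests on the fact that compounds 1 and 2 differ only in the configuration as drawn: the two are mirror images, and no other change accompanies it.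

Compound 3, `N/C(=N/O)c1cncc(N2CC[C@@H]3CN[C@@H]3C2)c1`, keeps the configuration of compound 2 and changes one place: a group of 4 heavy atoms (1 carbon, 2 nitrogen, 1 oxygen; no ring) in place of one bromine atom, on an aromatic carbon. The group that enters is built from one carbon, two nitrogens and one oxygen, and it sits on the same aromatic carbon where the bromine sat.

Going by the values given here, no measured step touches this kind of exchange. The step from compound 1 to compound 2 concerns configuration only and says nothing about what happens when a bromine is swapped for this larger group. The direction in this assay is therefore open, and a step of modest size either way would not be surprising, nor would none beyond the scatter. Compound 3 is expected to come in at 1200 nM, in a range from 300 nM to 5000 nM, which means an expected step of a 1.2-fold higher number from compound 2 to compound 3 (0.08 log units; within the scatter).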

Compound 3, half-maximal effective concentration: 180 nM
Beside the measured number, compound 3's estimate is 6.7-fold (0.82 log units) above it, and the stated range ends above it.
By their numbers in this assay, from the lowest: compounds 1 and 3 (each within the scatter of the next); then compound 2.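

In this assay, this position on the aromatic ring, two atoms from the ring nitrogen, responds to what sits on it: replacing bromo with the group of 4 heavy atoms gives a 5.6-fold lower number from compound 2 to compound 3 (0.74 log units; beyond the scatter). Among the compounds shown here, until now, the only change seen was in configuration, whereas this step shows that, with the configuration of compound 2 held fixed, the bromine can be exchanged for a larger group and the effect then appears at smaller amounts of compound. The entering group has 2 hydrogen-bond donors and 2 hydrogen-bond acceptors, while bromo has none, but nothing measured here accounts for the step.

From the compounds shown here alone, it remains open whether the same exchange would give a similar step in the mirror-image configuration of compound 1, which still carries the bromine. A single exchange also cannot show which part of the entering group matters, or whether a simpler group on the same aromatic carbon, such as an amine, a nitrile or a carboxylic acid, would move the number in the same direction.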